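Swapping Carbamoylmethyl for 4-methyl-1H-imidazol-2-yl

The compounds below may be only part of what the source reports. "The series", "measured", "known", "first", "only" and "open" are said of these compounds alone.

Compound 2 (`CC(C)C(CC(N)=O)c1ccc(-c2ccc3cccc(F)c3c2)[nH]c1=O`) stands at < 0.0667 h in an ADME assay on microsomes from liver (Mus musculus) for metabolic stability (on this read-out higher numbers stand for a longer-lived compound and lower numbers for a shorter-lived compound), and that value is only a limit. Compound 3 (`Cc1c[nH]c(C(c2ccc(-c3ccc4cccc(F)c4c3)[nH]c2=O)C(C)C)n1`) puts 4-methyl-1H-imidazol-2-yl in place of carbamoylmethyl on a saturated chain carbon bound to an aromatic carbon and a saturated chain carbon. For the measured compounds named here, the one measured step that bears on this is an at least 36-fold lower number from compound 1 to compound 2 (1.55 log units; beyond the scatter) and it is large. Compound 1 (`CC(C)C(Nc1nnc[nH]1)c1ccc(-c2ccc3cccc(F)c3c2)[nH]c1=O`) lacks carbamoylmethyl and gives 2.42 h as a measured number, so compound 3, also without that group, is expected to last longer. The expected change in this assay is an at least 8.9-fold higher number from compound 2 to compound 3 (0.95 log units; beyond the scatter) and this is a sizeable rise. For compound 3 the estimate is 0.6 h with an expected range from 0.1 h to 2.5 h in all.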

Compound 3, half-life: < 0.0667 h
Compound 3 was reported as a limit; the forecaster's own chance of this, stated with the estimate: 15%; middle value at least 8.9-fold (0.95 log units) from the limit.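

In this assay, 4-methyl-1H-imidazol-2-yl in place of (4H-1,2,4-triazol-3-yl)amino on this saturated chain carbon gives an at least 36-fold lower number from compound 1 to compound 3 (1.55 log units; beyond the scatter), so the short half-life does not belong to carbamoylmethyl alone. Of the three groups shown at this place, only (4H-1,2,4-triazol-3-yl)amino gives a value clear of the limit. The step from compound 2 to compound 3 cannot be read: the limit of < 0.0667 h in this assay, at which 2 of the 3 values shown sit.

On these data alone, how far compound 2 and compound 3 each lie from that limit remains open. Also open, as far as these compounds go, is whether a plain amine at this carbon would keep the half-life of compound 1.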